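This account rests on a few compounds, and the source may have more. Where it says the series, first, only, none or still open, it means among the compounds named here.

Working notes on the series. Three compounds carry numbers in a functional assay on aorta for antagonist activity at Alpha-1D adrenergic receptor (Rattus norvegicus); a lower number here means tighter binding, a higher number weaker binding: compound 1 `COc1ccccc1N1CCN(CCCNc2ncccc2C(=O)C2CC2)CC1` gives 2 nM, compound 2 `COc1ccccc1N1CCN(CCCNc2ccncc2C(=O)N(C(C)C)C(C)C)CC1` gives 251 nM, and compound 3 `CN(C)C(=O)c1cccnc1NCCCN1CCN(c2ccccc2O)CC1` gives 63.1 nM. Compound 3 thus stands second highest of the three; compound 2 sits beyond the scatter above it, and compound 1 lies beyond the scatter below it. Compound 4 `Cc1ccccc1N1CCN(CCCNc2ncccc2C(=O)N(C)C)CC1` is not yet measured. It differs from compound 3 in one place: methyl in place of hydroxy on an aromatic carbon, on an aromatic carbon of a six-membered aromatic ring of carbon only, ortho to a large group. Going by the values given here, no measured pair shows this exchange, so its size is open. The step from compound 3 to compound 4 is expected to be small, a 1.4-fold lower number from compound 3 to compound 4 (0.15 log units; within the scatter), not clearly beyond the scatter. Compound 4 is estimated at 45 nM, within 10 nM to 200 nM.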

Compound 4, dissociation constant: 10 nM
Beside the measured number, compound 4's estimate is 4.5-fold (0.65 log units) above it; the range from low to high includes it.
By their numbers in this assay, from the lowest: compound 1; then compound 4; then compound 3; then compound 2.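

Going by these compounds alone, the exchange of 2-hydroxyphenyl for 2-methylphenyl gives the first one-place comparison in this assay, with a 6.3-fold lower number from compound 3 to compound 4 (0.80 log units; beyond the scatter). This position therefore affects the read-out, and a lower number here does not depend on the hydroxy group or its hydrogen-bond donor. No supporting data on this step are available to explain it.

As far as these compounds go, what an amine or a chlorine atom at this place would give stays open. So does whether the same exchange would give a step of similar size on the core of compound 1 or compound 2.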